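The source may report more compounds than this note shows. Statements on the series, on what has been measured and on what is new or still open speak of the compounds shown alone.

Working notes on the series. The shared core is that of compound 1 `Cn1nc(-c2cccnc2)c2ccccc2c1=O`, which in a functional assay (trachea) with Cavia porcellus as the target (on this read-out higher numbers stand for weaker inhibition and lower numbers for stronger inhibition), gives 11500 nM. Compound 2 `CC(C)=CCn1nc(-c2cccnc2)c2ccccc2c1=O` gives 1380 nM in this assay and so stands lowest of the three numbers measured; compound 3 `O=c1c2ccccc2c(-c2cccnc2)nn1CCSc1nccs1` gives 10500 nM. The step of an 8.3-fold lower number from compound 1 to compound 2 (0.92 log units; beyond the scatter) is the one clear gain in the set, while a 7.6-fold higher number from compound 2 to compound 3 (0.88 log units; beyond the scatter) takes most of it back again and a 1.1-fold lower number from compound 1 to compound 3 (0.04 log units; within the scatter) leaves compounds 1 and 3 indistinguishable.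

Compound 4 `O=c1c2ccccc2c(-c2cccnc2)nn1CCO` is not yet measured in this assay. Relative to compound 2 it carries hydroxymethyl in place of 2-methylprop-1-en-1-yl on a saturated chain carbon bound to an aromatic nitrogen.

For the measured compounds named here, two measured steps bear on this. Both an 8.3-fold lower number from compound 1 to compound 2 (0.92 log units; beyond the scatter) and a 7.6-fold higher number from compound 2 to compound 3 (0.88 log units; beyond the scatter) say that the number is sensitive to what sits on the saturated chain carbon bound to the aromatic nitrogen, and that the 2-methylprop-1-en-1-yl group is the only substituent so far that has carried a lower number. Hydroxymethyl is smaller still than what enters in compound 3, so the expectation is a step of a size comparable to a 7.6-fold higher number from compound 2 to compound 3 (0.88 log units; beyond the scatter), with the number rising back toward compound 1. Compound 4 is therefore estimated at 7500 nM, range 2500 nM to 22000 nM, an expected step of a 5.4-fold higher number from compound 2 to compound 4 (0.74 log units; beyond the scatter).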

Compound 4, half-maximal inhibitory concentration: 4570 nM
Beside the measured number, compound 4's estimate is 1.6-fold (0.22 log units) above it, within the range that was stated.
By their numbers in this assay, from the lowest: compound 2; then compound 4; then compounds 3 and 1 (each within the scatter of the next).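

In this assay the chain on the aromatic nitrogen no longer needs the 3-methylbut-2-en-1-yl group to lower the number, since the 2-hydroxyethyl chain of compound 4 also gives a gain beyond the scatter over the methyl of the shared core (a 2.5-fold lower number from compound 1 to compound 4 (0.40 log units; beyond the scatter)). For the compounds shown here, that gain stops short of the one carried by compound 2, and the exchange of 2-methylprop-1-en-1-yl for hydroxymethyl, which brings in a hydrogen-bond donor and acceptor and removes the double bond, costs part of it (a 3.3-fold higher number from compound 2 to compound 4 (0.52 log units; beyond the scatter)). The end of the two-carbon chain also matters, as hydroxy in place of (1,3-thiazol-2-yl)sulfanyl lowers the number (a 2.3-fold lower number from compound 3 to compound 4 (0.36 log units; beyond the scatter)), though no available data explain any of these steps.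

Open, from the compounds shown here alone, is whether the gain of compound 2 depends on the double bond or on the branching, which a saturated 3-methylbutyl chain would separate. Also open, going by these compounds, is whether hydroxy is a good end group in its own right, which a methoxy, an amine, a carboxylic acid or a longer chain ending in hydroxy would test at the same place.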